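This account rests on a few compounds, and the source may have more. Where it says the series, first, only, none or still open, it means among the compounds named here.

The measured compounds and their values in a functional assay on NCI-H460 cells (Homo sapiens) for inhibition, read by MTT assay, with a stated time of 72 h; on this read-out higher numbers stand for weaker inhibition and lower numbers for stronger inhibition:
compound 1, `COc1cc2c(Oc3ccc(NC(=O)c4nn(-c5ccccc5C)c(=O)cc4C)cc3F)ccnc2cc1OCCCN1CCCCC1`, gives 3220 nM;
compound 2, `COc1cc2c(Oc3ccc(NC(=O)c4nn(-c5cccc(F)c5)c(=O)cc4C)cc3F)ccnc2cc1OCCCN1CCCCC1`, gives 360 nM;
compound 3, `COc1cc2c(Oc3ccc(NC(=O)c4nn(-c5cccc(F)c5)c(=O)cc4C)cc3F)ccnc2cc1OCCCN1CCN(C)CC1`, gives 260 nM.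

Within this small set compound 2 holds the second highest number in this assay. Its nearest neighbour is compound 3, with a 1.4-fold lower number from compound 2 to compound 3 (0.14 log units; within the scatter), a gap that lies within the usual scatter, and its furthest is compound 1, with an 8.9-fold lower number from compound 1 to compound 2 (0.95 log units; beyond the scatter).

Compound 4, `COc1cc2c(Oc3ccc(NC(=O)c4nn(-c5ccc(Cl)cc5Cl)c(=O)cc4C)cc3F)ccnc2cc1OCCCN1CCCCC1`, has not yet been measured. It differs from compound 2 in one place: 2,4-dichlorophenyl in place of 3-fluorophenyl on an aromatic nitrogen. For the measured compounds named here, of the two measured steps, only the one from compound 1 to compound 2 changes the group on this aromatic nitrogen, and that step was sizeable: an 8.9-fold lower number from compound 1 to compound 2 (0.95 log units; beyond the scatter). The other step, from compound 2 to compound 3, alters a distant chain end and stays within the scatter, so it says nothing about this position. A single step at one position gives no rule for a third group, so the direction remains uncertain, and a move of moderate size either way would not be surprising. The expected outcome is a number somewhat higher than that of compound 2, meaning an expected step of a 3.3-fold higher number from compound 2 to compound 4 (0.52 log units; beyond the scatter). Compound 4 is therefore estimated at 1200 nM, with a likely range from 350 nM to 5000 nM.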

Compound 4, half-maximal inhibitory concentration: 390 nM
Beside the measured number, compound 4's estimate is 3.1-fold (0.49 log units) above it; measured number inside the range.
By their numbers in this assay, from the lowest: compounds 3, 2 and 4 (each within the scatter of the next); then compound 1.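

In this assay the group on the aromatic nitrogen can now be compared across three versions, and 3-fluorophenyl and 2,4-dichlorophenyl cannot be told apart (a 1.1-fold higher number from compound 2 to compound 4 (0.03 log units; within the scatter)). The same 2,4-dichlorophenyl group stands well clear of 2-methylphenyl (an 8.3-fold lower number from compound 1 to compound 4 (0.92 log units; beyond the scatter)), so the gap first seen between compound 1 and compound 2 appears again with a second, quite different group. This position therefore accepts two chlorine atoms as readily as one fluorine, and although the names 2-methylphenyl and 2,4-dichlorophenyl both carry a substituent numbered 2, only compound 1 stands apart, so that number alone does not go with the weaker result.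

Nothing given here explains why 2-methylphenyl stands apart from the other two groups. Also open, going by these compounds, is whether a 2-chlorophenyl group, or a phenyl ring bearing an amine or a carboxylic acid, would fall with compound 2 and compound 4 or with compound 1, and whether the 4-methylpiperazin-1-yl chain end would behave the same alongside 2,4-dichlorophenyl.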